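Replacing the cyclopentylmethyl amide of compound 1 with an imidazole

The compounds below may be only part of what the source reports. "The series", "measured", "known", "first", "only" and "open" are said of these compounds alone.

Compound 1, with the structure `CCCC(=O)N1CCC(NS(=O)(=O)c2ccc(NC(=O)CC3CCCC3)c3ccccc23)CC1`, is the weakest of the three measured compounds: in an in vitro functional assay on CHO/Galpha16 cells for antagonist activity at C-C chemokine receptor type 8 (Homo sapiens), read by FLIPR (on this read-out higher numbers stand for weaker inhibition and lower numbers for stronger inhibition), compound 1 gives 145 nM. Compound 2 `CCCC(=O)N1CCC(NS(=O)(=O)c2ccc(NC(=O)C3CCCCC3)c3ccccc23)CC1` gives 6.1 nM, and compound 3 `CCCC(=O)N1CCC(NS(=O)(=O)c2ccc(NC(=O)c3ccc(CC)cc3)c3ccccc23)CC1` gives 10.8 nM. Both neighbours sit clearly lower than compound 1, with a 24-fold lower number from compound 1 to compound 2 (1.38 log units; beyond the scatter) and a 13-fold lower number from compound 1 to compound 3 (1.13 log units; beyond the scatter), while the two of them lie close together, as a 1.8-fold higher number from compound 2 to compound 3 (0.25 log units; within the scatter) shows.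

Compound 4, `CCCC(=O)N1CCC(NS(=O)(=O)c2ccc(NC(=O)c3nccn3C)c3ccccc23)CC1`, differs from compound 1 at the same carbonyl carbon: 1-methyl-1H-imidazol-2-yl in place of cyclopentylmethyl on a carbonyl carbon. As in compound 2 and compound 3, a ring is set directly on the carbonyl carbon in place of the cyclopentylmethyl group. Going by the values given here, those two steps were both large and both pointed to a lower number, so a drop in the same direction is expected for compound 4, though the imidazole with its two nitrogen atoms has no measured counterpart, which leaves the size uncertain. The expected step is a 7.3-fold lower number from compound 1 to compound 4 (0.86 log units; beyond the scatter). For compound 4 the estimated value is 20 nM, within a range from 5 nM to 80 nM.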

Compound 4, half-maximal inhibitory concentration: 20.4 nM
The estimate for compound 4 lay 1.0-fold (0.01 log units) below the measured number; the measured number falls inside the stated range.
By their numbers in this assay, from the lowest: compounds 2, 3 and 4 (each within the scatter of the next, the first and the last beyond it); then compound 1.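

In this assay, this position tolerates an aromatic ring that carries nitrogen atoms, not only the carbon-only rings of compound 2 and compound 3: swapping out cyclopentylmethyl still gives a clear drop (a 7.1-fold lower number from compound 1 to compound 4 (0.85 log units; beyond the scatter)). The 1-methyl-1H-imidazol-2-yl group cannot be told apart from 4-ethylphenyl (a 1.9-fold higher number from compound 3 to compound 4 (0.28 log units; within the scatter)), yet it does lose modest ground to cyclohexyl (a 3.3-fold higher number from compound 2 to compound 4 (0.52 log units; beyond the scatter)), so the choice of ring directly on the carbonyl carbon still matters somewhat. No supporting measurement is available to explain these differences.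

On these data alone, it remains open what an amine or a carboxylic acid carried on this ring would do, and whether the methyl of the imidazole is needed. A cyclopentyl group set directly on the carbonyl carbon would also show whether the ring's direct attachment or its size matters more.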